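This account rests on a few compounds, and the source may have more. Where it says the series, first, only, none or still open, it means among the compounds named here.

Measured so far in a functional assay on cells (Splenocyte, Mus musculus, strain BALB/c) for inhibition, read by scintillation counting and thymidine incorporation, with a stated time of 72 h; a lower number here means a stronger inhibitor, a higher number a weaker inhibitor:
Compound 1 `CC(/C=N/Nc1ccc([N+](=O)[O-])cc1)=N\NC(=O)c1ccccc1` gives > 12000 nM, which is a limit of this assay rather than a number.
Compound 2 `CC(/C=N/Nc1ccc([N+](=O)[O-])cc1)=N\NC(=O)c1ccccc1O` gives 1640 nM.
Compound 3 `CC(/C=N/Nc1ccc([N+](=O)[O-])cc1)=N\NC(=O)c1ccc(N)cc1` gives > 12000 nM, again a limit and not a number.

Compound 3 thus stands at the weak end of what has been seen: it sits at the limit named in the limit of > 12000 nM in this assay, at which 2 of the 3 values shown sit, where compound 1 sits as well, and only compound 2 has a read number beneath it. The step to compound 4 `CC(/C=N/Nc1ccc([N+](=O)[O-])cc1)=N\NC(=O)c1ccccc1F` is 2-fluorophenyl in place of 4-aminophenyl on a carbonyl carbon. Since this exchanges one substituted phenyl on the carbonyl carbon for another, the measured step that bears on it most directly is an at least 7.3-fold higher number from compound 2 to compound 3 (0.86 log units; beyond the scatter), which shows the 4-aminophenyl of compound 3 falling well behind the 2-hydroxyphenyl of compound 2. The step of an at least 7.3-fold lower number from compound 1 to compound 2 (0.86 log units; beyond the scatter) shows that same 2-hydroxyphenyl well ahead of plain phenyl, whereas a step that the two limits leave unreadable from compound 1 to compound 3 cannot be sized. Compound 4 carries a 2-fluorophenyl that, unlike the 2-hydroxyphenyl of compound 2, brings no hydrogen-bond donor, so the gain seen for compound 2 is not expected to carry over in full. In this assay compound 4 is therefore expected to move only a little from compound 3, as an at least 1.5-fold lower number from compound 3 to compound 4 (0.17 log units; that floor lies within the scatter), with a fair chance of another limit. The estimate for compound 4 is 8000 nM, within 2500 nM to 30000 nM.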

Compound 4, half-maximal inhibitory concentration: > 12000 nM
Compound 4 gave a limit, no number (the forecaster's own chance of this, stated with the estimate: 50%); at least 1.5-fold (0.17 log units) between middle value and limit.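

In this assay, for the compounds shown here, the exchange of hydroxy for fluoro on the aromatic carbon gives an at least 7.3-fold higher number from compound 2 to compound 4 (0.86 log units; beyond the scatter), which is the first direct comparison at this place between two groups on the same phenyl. Going by these compounds alone, a hydroxy group on this ring thus cannot be replaced by fluoro without the loss of a read number, and a substituent at this place is not enough in itself, since compound 2 remains the only compound with a number and the rest of the series now gathers at one limit: the limit of > 12000 nM in this assay, at which 3 of the 4 values shown sit. The steps from compound 1 and from compound 3 to compound 4 cannot be read, with limits at both ends, so the 2-fluorophenyl cannot be ranked against plain phenyl or 4-aminophenyl.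

On these data alone, it remains open whether a methoxy or an amine in place of the hydroxy of compound 2 would also give a read number on the shared core. Also open, as far as these compounds go, is how compound 1, compound 3 and compound 4 truly compare, with no number standing for any of them.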